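The source may hold more compounds than are shown below. What is called first, only, known or untested is meant among the compounds shown, and "the series" means these compounds.

In a functional assay on HepG2 cells (Homo sapiens) for antiproliferative activity, read by MTT assay, with a stated time of 48 h (on this read-out higher numbers stand for weaker inhibition and lower numbers for stronger inhibition), compound 1 `COc1ccccc1NC(=O)Nc1cccc(CNc2nccnc2Cl)c1` gives 13700 nM and compound 3 `Cc1ccc(NC(=O)Nc2cccc(CNc3nccnc3Cl)c2)c(C)c1` gives 9290 nM. These two values lie within the scatter of each other, as the step of a 1.5-fold lower number from compound 1 to compound 3 (0.17 log units; within the scatter) shows. For compound 2 `CN(C)c1ccc(NC(=O)Nc2cccc(CNc3nccnc3Cl)c2)cc1` the assay reports only a limit, > 40000 nM. The steps of an at least 2.9-fold higher number from compound 1 to compound 2 (0.46 log units; beyond the scatter) and an at least 4.3-fold lower number from compound 2 to compound 3 (0.63 log units; beyond the scatter) both lie beyond the scatter. Compound 4 `Cc1ccc(NC(=O)Nc2cccc(CNc3nccnc3Cl)c2)cc1C` keeps the atoms of compound 3 but joins them differently: 3,4-dimethylphenyl in place of 2,4-dimethylphenyl on an amide-type nitrogen. Among the compounds with values here, no measured step tests this exact change. The nearest guide is the step of a 1.5-fold lower number from compound 1 to compound 3 (0.17 log units; within the scatter), which also exchanges one group on that nitrogen and stays within the scatter. The expected change is therefore none beyond the scatter, and the estimated step is a 1.1-fold higher number from compound 3 to compound 4 (0.03 log units; within the scatter). For compound 4 the estimated value is 10000 nM, with an expected range from 4500 nM to 25000 nM.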

Compound 4, half-maximal inhibitory concentration: 10700 nM
The estimate for compound 4 lay 1.1-fold (0.03 log units) below the measured number; low and high end bracket the measured number.
By their numbers in this assay, from the lowest: compounds 3, 4 and 1 (each within the scatter of the next). At a limit, above all of these: compound 2.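

Exchanging 2,4-dimethylphenyl for 3,4-dimethylphenyl on the amide-type nitrogen leaves the number within the scatter (a 1.2-fold higher number from compound 3 to compound 4 (0.06 log units; within the scatter)), so here the two dimethylphenyl patterns cannot be told apart. The 3,4-dimethylphenyl group also stays within the scatter of 2-methoxyphenyl (a 1.3-fold lower number from compound 1 to compound 4 (0.11 log units; within the scatter)), while the gap to 4-(dimethylamino)phenyl lies beyond it (an at least 3.7-fold lower number from compound 2 to compound 4 (0.57 log units; beyond the scatter)). For compound 2 the value is only a limit: the limit of > 40000 nM in this assay, at which 1 of the 4 values shown sits. On these data alone, what a carboxylic acid or a morpholine on that nitrogen would give remains open. So does whether any group there gives a number clearly lower than these.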